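The compounds below may be only part of what the source reports. "The series", "measured", "known", "first", "only" and "open" are said of these compounds alone.

Working notes on the series. The shared core carries a triazole whose nitrogen bears a benzylic arm; three members have been run in a functional assay on HeLa cells (Homo sapiens) for cytotoxicity, read by MTT assay, with a stated time of 48 h; a higher number here means a weaker inhibitor, a lower number a stronger inhibitor. Compound 1 `Cc1ccc(Cn2cc(COc3ccc4c(=O)ccoc4c3)nn2)cc1` gives in this assay a value that is only a limit of the assay, > 100000 nM. Compound 2 `O=c1ccoc2cc(OCc3cn(Cc4ccc(Cl)cc4Cl)nn3)ccc12` gives in this assay 80600 nM. Compound 3 `O=c1ccoc2cc(OCc3cn(Cc4cccc(Cl)c4)nn3)ccc12` gives in this assay a limit, > 100000 nM. The steps among them are small or unreadable: an at least 1.2-fold lower number from compound 1 to compound 2 (0.09 log units; that floor lies within the scatter), an at least 1.2-fold higher number from compound 2 to compound 3 (0.09 log units; that floor lies within the scatter), and a step that the two limits leave unreadable from compound 1 to compound 3. Most of the set sits at the ceiling, as the limit of > 100000 nM in this assay, at which 2 of the 3 values shown sit, shows.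

Compound 4 `O=c1ccoc2cc(OCc3cn(Cc4cccc([N+](=O)[O-])c4)nn3)ccc12` is to be measured in this assay. It differs from compound 3 by nitro in place of chloro on an aromatic carbon. Among the compounds with values here, none of the measured steps swaps a halogen for a nitro group, so no step bears directly; what they show is a series that does not move beyond the scatter and mostly rests at the limit. The expectation for compound 4 is therefore no change beyond the scatter, a step that the limit leaves unreadable from compound 3 to compound 4, with a high chance of another limit. The estimate for compound 4 in this assay is 150000 nM, between 60000 nM and 400000 nM.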

Compound 4, half-maximal inhibitory concentration: 17300 nM
Beside the measured number, compound 4's estimate is 8.7-fold (0.94 log units) above it; the whole stated range lies above it.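

Chloro to nitro on this aromatic carbon, meta to a large group, is the first change in the series that clearly moves the number in this assay, giving an at least 5.7-fold lower number from compound 3 to compound 4 (0.76 log units; beyond the scatter); this is a floor rather than a full size, since the value of compound 3 is a limit. The 3-nitrophenyl arm also stands clear of the other two arms, with a 4.7-fold lower number from compound 2 to compound 4 (0.67 log units; beyond the scatter) and an at least 5.7-fold lower number from compound 1 to compound 4 (0.76 log units; beyond the scatter), so compound 4 now has the lowest number of the four. Compound 1 and compound 3 remain at the ceiling: the limit of > 100000 nM in this assay, at which 2 of the 4 values shown sit.

From the compounds shown here alone, whether nitro elsewhere on the aromatic ring would give a similar number remains open. So does whether another group on this same carbon, such as an amine or a nitrile, would match compound 4.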